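Working notes: from compound 3 to compound 4

A few compounds are considered here, and "the series" means these few. Any claim that something is new, unique, unknown or untested is made for them only; others in the source may bear on it.

Values in a functional assay on MDA-MB-231 cells (Homo sapiens) for inhibition, read by MTT assay, with a stated time of 72 h (a higher number here means a weaker inhibitor, a lower number a stronger inhibitor), follow, each a limit and not a number:
compound 1 `Cc1ccc(-c2cc(C(=O)N3CCC4(CC3)CC(=O)c3nn(C(C)(C)C)cc3O4)c3ccccc3n2)cc1` gives > 10000 nM as a limit
compound 2 `CC(C)(C)n1cc2c(n1)C(=O)CC1(CCN(C(=O)c3cc(-c4ccccc4Cl)nc4ccccc34)CC1)O2` gives > 10000 nM as a limit
compound 3 `CN(C)c1ccc(-c2cc(C(=O)N3CCC4(CC3)CC(=O)c3nn(C(C)(C)C)cc3O4)c3ccccc3n2)cc1` gives > 10000 nM as a limit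

Compound 3 stands at > 10000 nM in this assay and this is a limit. All three compounds share it (the limit of > 10000 nM in this assay, at which 3 of the 3 values shown sit). Compound 4 `CC(C)(C)n1cc2c(n1)C(=O)CC1(CCN(C(=O)c3cc(-c4ccccn4)nc4ccccc34)CC1)O2` carries pyridin-2-yl in place of 4-(dimethylamino)phenyl on an aromatic carbon. Among the measured compounds shown here, three measured steps bear on this change (a step that the two limits leave unreadable from compound 1 to compound 2; a step that the two limits leave unreadable from compound 1 to compound 3; a step that the two limits leave unreadable from compound 2 to compound 3), and none has a readable size. No step beyond the scatter and no direction can be drawn from them. The expected step is therefore small and unsigned (a step that the limit leaves unreadable from compound 3 to compound 4). Compound 4 is estimated at 12000 nM with an expected range from 4000 nM to 30000 nM in this assay again.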

Compound 4, half-maximal inhibitory concentration: 8100 nM
Compound 4: middle estimate off by 1.5-fold (0.17 log units), on the high side, and the stated range covers the measured number.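

Compound 4, with pyridin-2-yl on the aromatic carbon next to the ring nitrogen, is the only compound shown that gives a number rather than a limit in this assay. The steps to it are an at least 1.2-fold lower number from compound 3 to compound 4 (0.09 log units; that floor lies within the scatter), an at least 1.2-fold lower number from compound 2 to compound 4 (0.09 log units; that floor lies within the scatter) and an at least 1.2-fold lower number from compound 1 to compound 4 (0.09 log units; that floor lies within the scatter), so no gain beyond the scatter is established for this change. The other values remain limits: the limit of > 10000 nM in this assay, at which 3 of the 4 values shown sit.

On these data alone, whether plain phenyl, pyridin-3-yl or a group carrying a carboxylic acid at this position would give a lower number stays open.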